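The source may report more compounds than this note shows. Statements on the series, on what has been measured and on what is new or still open speak of the compounds shown alone.

Compound 1 `C#CCSc1nc(Nc2ccc(OC)cc2)c(C#N)c(-c2ccccc2)n1`: 9710 nM in a functional assay on B16-F10 cells (Mus musculus) for inhibition, read by MTT assay, with a stated time of 72 h; on this read-out lower numbers stand for stronger inhibition and higher numbers for weaker inhibition
Compound 2 `C#CCSc1nc(Nc2ccc(Cl)cc2)c(C#N)c(-c2ccccc2)n1`: 19800 nM in this assay
Compound 3 `COc1ccc(Nc2nc(SCc3cn(Cc4ccccc4Cl)nn3)nc(-c3ccccc3)c2C#N)cc1`: 3990 nM in this assay

These three compounds share one core, a nitrile-bearing ring carrying a phenyl group, an arylamino group and a sulfur-linked side chain, and all were measured in this assay. Compound 3, which carries the larger triazole-containing side chain, gives the lowest number of the three. Compound 1 stands nearest to it, and compound 2 furthest; both gaps lie beyond the scatter of repeated measurements.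

Compound 4 `N#Cc1c(Nc2ccc(Cl)cc2)nc(SCc2cn(Cc3ccccc3Cl)nn2)nc1-c1ccccc1` has not yet been measured. It differs from compound 3 in a single place: chloro in place of methoxy on an aromatic carbon. Among the measured compounds shown here, one measured step bears directly on this change, since compounds 1 and 2 differ by exactly the same swap on the smaller side chain: a 2.0-fold higher number from compound 1 to compound 2 (0.31 log units; beyond the scatter). That step went toward a higher number, meaning weaker inhibition, and was modest but beyond the scatter. On this basis the same change on the larger side chain is expected to move the number in the same direction by a similar amount, so the step of a 2.0-fold higher number from compound 3 to compound 4 (0.30 log units; within the scatter) is the expected outcome. Compound 4 is therefore estimated at 8000 nM, with a likely range from 3500 nM to 18000 nM.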

Compound 4, half-maximal inhibitory concentration: 1590 nM
The estimate for compound 4 lay 5.0-fold (0.70 log units) above the measured number, and the stated range ends above it.
By their numbers in this assay, from the lowest: compound 4; then compound 3; then compound 1; then compound 2.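

On the side chain that carries the triazole, replacing (4-methoxyphenyl)amino with (4-chlorophenyl)amino strengthens inhibition in this assay, giving a 2.5-fold lower number from compound 3 to compound 4 (0.40 log units; beyond the scatter). The earlier pair, with its smaller side chain, had pointed the other way, so this swap has no single direction of effect across the shared core. Neither chloro nor methoxy can therefore be called the better group at this place in general, and each reading holds only with its own side chain, as the two steps differ by more than the scatter allows: the same change on two cores in this assay, a 2.0-fold higher number (0.31 log units; beyond the scatter) from compound 1 to compound 2 and a 2.5-fold lower number (0.40 log units; beyond the scatter) from compound 3 to compound 4, 5.1-fold (0.71 log units) apart, beyond the scatter of two such steps.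

As far as these compounds go, what remains open is how far this reversal extends, since the comparison rests on just two side chains and two groups at this place. A fluoro, a methyl or an amine in the same place might follow either trend, and it is also unclear whether the chloro gain would persist if the chloro on the benzyl group of the side chain gave way to a methoxy or a carboxylic acid.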